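Heteroaryl enones on a shared nitrocatechol core: furan-2-yl step

The source may report more compounds than this note shows. Statements on the series, on what has been measured and on what is new or still open speak of the compounds shown alone.

In an assay on isolated protein for inhibition of Amine oxidase [flavin-containing] B (Homo sapiens), read by fluorescence (a lower number here means a stronger inhibitor, a higher number a weaker inhibitor), the three measured compounds read as follows.
Compound 1 `O=C(/C=C/c1ccoc1)c1cc(O)c(O)c([N+](=O)[O-])c1`: 71400 nM
Compound 2 `O=C(/C=C/c1nccs1)c1cc(O)c(O)c([N+](=O)[O-])c1`: 59200 nM
Compound 3 `O=C(/C=C/c1cccs1)c1cc(O)c(O)c([N+](=O)[O-])c1`: 62900 nM

Compound 3 holds the second highest of these three numbers in this assay. Its nearest neighbour is compound 2, the pair showing a 1.1-fold higher number from compound 2 to compound 3 (0.03 log units; within the scatter); the furthest is compound 1, the pair showing a 1.1-fold lower number from compound 1 to compound 3 (0.06 log units; within the scatter). The remaining pair shows a 1.2-fold lower number from compound 1 to compound 2 (0.08 log units; within the scatter). Among the compounds with values here, every exchange of one heteroaryl group for another on the double-bonded chain carbon has so far stayed inside the scatter, with no compound standing apart.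

Compound 4 `O=C(/C=C/c1ccco1)c1cc(O)c(O)c([N+](=O)[O-])c1` differs from compound 3 in one place: furan-2-yl in place of thiophen-2-yl on a double-bonded chain carbon bound to a double-bonded chain carbon. The three measured steps are the ones that bear on this change, and none of them moved the number beyond the scatter. The expectation for compound 4 in this assay is therefore no step beyond the scatter, a step of about a 1.0-fold higher number from compound 3 to compound 4 (0.01 log units; within the scatter). Compound 4 is estimated at 65000 nM, with a range from 30000 nM to 140000 nM.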

Compound 4, half-maximal inhibitory concentration: 68200 nM
Compound 4: middle estimate off by 1.0-fold (0.02 log units), on the low side, and the stated range covers the measured number.
By their numbers in this assay, from the lowest: compounds 2, 3, 4 and 1 (each within the scatter of the next).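

Furan-2-yl in place of thiophen-2-yl on a double-bonded chain carbon bound to a double-bonded chain carbon stays within the scatter in this assay (a 1.1-fold higher number from compound 3 to compound 4 (0.04 log units; within the scatter)). The same holds for furan-2-yl in place of 1,3-thiazol-2-yl (a 1.2-fold higher number from compound 2 to compound 4 (0.06 log units; within the scatter)) and for furan-2-yl in place of furan-3-yl (a 1.0-fold lower number from compound 1 to compound 4 (0.02 log units; within the scatter)), so neither the choice of hetero atom among these rings nor the furan attachment point separates these compounds. No supporting data offer an explanation for this flat result.

As far as these compounds go, all four groups at this place are five-membered aromatic rings, so the effect of a phenyl ring, a pyridine ring or a ring bearing a carboxylic acid remains open. From the compounds shown here alone, whether any group here can move the number beyond the scatter also remains open.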